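The source may report more compounds than this note shows. Statements on the series, on what has been measured and on what is new or still open speak of the compounds shown alone.

In a functional assay on HCT-15 cells (Homo sapiens) for inhibition, read by MTT assay, with a stated time of 72 h (on this read-out lower numbers stand for stronger inhibition and higher numbers for weaker inhibition), compound 1 `COc1cc(Oc2cccc(Nc3ccccc3)c2)cc(OC)c1CNCCNC(C)=O` gives 5090 nM, compound 2 `COc1cc(Oc2cccc(Nc3ccccc3)c2)cc(OC)c1CNCc1ccc(C)cc1` gives 5400 nM and compound 3 `COc1cc(Oc2cccc(Nc3ccccc3)c2)cc(OC)c1CNCc1ccc(Cl)cc1` gives 4850 nM, so compound 3 stands level with both others within the scatter. Compound 4 `COc1cc(Oc2cccc(Nc3ccccc3)c2)cc(OC)c1CNC(C)C` follows from compound 3 by one change: isopropyl in place of 4-chlorobenzyl on an amine nitrogen. The nearest evidence is the swap of acetamidomethyl for 4-chlorophenyl, a 1.0-fold lower number from compound 1 to compound 3 (0.02 log units; within the scatter), the swap for 4-methylphenyl, a 1.1-fold higher number from compound 1 to compound 2 (0.03 log units; within the scatter), and chloro in place of methyl, a 1.1-fold lower number from compound 2 to compound 3 (0.05 log units; within the scatter). All three lie within the scatter. Going by the values given here, no measured compound carries isopropyl, so the range stays wide. The expected change is a 1.1-fold higher number from compound 3 to compound 4 (0.05 log units; within the scatter), with no step beyond the scatter anticipated. For compound 4 the estimated value is 5500 nM, within an expected range of 2500 nM to 11000 nM.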

Compound 4, half-maximal inhibitory concentration: > 20000 nM
Compound 4 gave a limit, no number; the forecaster's own chance of this, stated with the estimate: 3%; middle value at least 3.6-fold (0.56 log units) away from the limit.
By their numbers in this assay, from the lowest: compounds 3, 1 and 2 (each within the scatter of the next). At a limit, above all of these: compound 4.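

The value of compound 4 in this assay is a limit, not a number: the limit of > 20000 nM in this assay, at which 1 of the 4 values shown sits. The amine nitrogen had looked tolerant, since 4-chlorobenzyl, 4-methylbenzyl and 2-acetamidoethyl stood level within the scatter, but isopropyl separates from all three: an at least 4.1-fold higher number from compound 3 to compound 4 (0.61 log units; beyond the scatter) and an at least 3.7-fold higher number from compound 2 to compound 4 (0.56 log units; beyond the scatter) and an at least 3.9-fold higher number from compound 1 to compound 4 (0.59 log units; beyond the scatter). This position is therefore not indifferent to its substituent.

On these data alone, how far compound 4 lies past its limit stays open. Also open, as far as these compounds go, is whether an unbranched n-propyl chain or a cyclohexyl group on this nitrogen would stand level with compound 3 or go the way of compound 4.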